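From Oxan-4-yl to Ethyl: Expected Clearance Shift

The source may report more compounds than this note shows. Statements on the series, on what has been measured and on what is new or still open speak of the compounds shown alone.

Of the compounds shown here, three built on the same core have been measured in an ADME assay on microsomes from liver (Homo sapiens) for metabolic stability; on this read-out higher numbers stand for fast clearance and lower numbers for slow clearance. Compound 1 `CC(C)n1nc(-c2ccnc3[nH]c(C4CCN(CC(=O)N(C)C)CC4)cc23)ccc1=O` gives 13 uL/min. Compound 2 `CC(C)Cn1cc(-c2ccnc3[nH]c(C4CCN(CC(=O)N(C)C)CC4)cc23)ccc1=O` gives 21 uL/min. Compound 3 `CN(C)C(=O)CN1CCC(c2cc3c(-c4ccc(=O)n(C5CCOCC5)c4)ccnc3[nH]2)CC1` gives 8.2 uL/min. The number for compound 3 lies within the usual scatter of compound 1, so those two cannot be told apart, whereas the step of a 2.6-fold lower number from compound 2 to compound 3 (0.41 log units; beyond the scatter) lies beyond the scatter and is the only clear difference among the three.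

The next compound, compound 4 `CCn1cc(-c2ccnc3[nH]c(C4CCN(CC(=O)N(C)C)CC4)cc23)ccc1=O`, differs from compound 3 in a single place: ethyl in place of oxan-4-yl on an aromatic nitrogen. For the measured compounds named here, the one measured step that bears on this is a 2.6-fold lower number from compound 2 to compound 3 (0.41 log units; beyond the scatter), where the oxan-4-yl group on the aromatic nitrogen came in for an isobutyl group and the number fell. Compound 4 undoes that kind of change, putting a short alkyl chain, ethyl, back in place of oxan-4-yl. Because of a 2.6-fold lower number from compound 2 to compound 3 (0.41 log units; beyond the scatter) a rise of modest size is expected for compound 4, and the chain is shorter than isobutyl, so the step is estimated as a 1.8-fold higher number from compound 3 to compound 4 (0.26 log units; within the scatter). The value for compound 4 in this assay is therefore estimated at 15 uL/min, expected to fall between 8 uL/min and 28 uL/min.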

Compound 4, intrinsic clearance in a liver preparation (reported as CLH), per the amount of preparation that the assay uses: < 3 uL/min
Compound 4 was reported as a limit (the forecaster's own chance of this, stated with the estimate: 5%); middle value at least 5.0-fold (0.69 log units) away from the limit.
By their numbers in this assay, from the lowest: compounds 3, 1 and 2 (each within the scatter of the next, the first and the last beyond it). At a limit, below all of these: compound 4.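

In this assay compound 4 is reported only as a limit: the limit of < 3 uL/min in this assay, at which 1 of the 4 values shown sits.

Even so, ethyl in place of oxan-4-yl on the aromatic nitrogen gives an at least 2.7-fold lower number from compound 3 to compound 4 (0.43 log units; beyond the scatter), and methyl in place of isopropyl on the saturated chain carbon bound to that nitrogen gives an at least 7.0-fold lower number from compound 2 to compound 4 (0.84 log units; beyond the scatter), so on this core a plain alkyl group at this position does not by itself bring a high number, and the length of the chain matters. The remaining comparison, an at least 4.3-fold lower number from compound 1 to compound 4 (0.63 log units; beyond the scatter), swaps a whole group on an aromatic carbon, so it cannot be tied to any single atom of that group.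

On these data alone, the true number for compound 4 stays unknown, so how far ethyl really lies from oxan-4-yl and isobutyl remains open. A methyl or a propyl group on the aromatic nitrogen would show whether the number changes step by step with chain length or only once the chain reaches isobutyl.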